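This account rests on a few compounds, and the source may have more. Where it says the series, first, only, none or still open, it means among the compounds named here.

In an ADME assay on the whole organism (strain CD1) for pharmacokinetics, with Mus musculus as the target, read by LC-MS, at a dose of 5 mg/kg by the oral route (on this read-out higher numbers stand for higher oral bioavailability and lower numbers for lower oral bioavailability), compound 1 `Cc1c(Oc2cnc(C(=O)NCCO)cn2)ccc2c1B(O)OC2` gives 94% and compound 2 `Cc1c(Oc2cnc(C(=O)NC(C)CO)cn2)ccc2c1B(O)OC2` gives 85% on the shared core, which leaves compound 2 level with compound 1 within the scatter. Compound 3 `CCC[C@H](CO)NC(=O)c1cnc(Oc2ccc3c(c2C)B(O)OC3)cn1` follows from compound 2 through 1-(hydroxymethyl)butyl in place of 1-(hydroxymethyl)ethyl on an amide-type nitrogen and so carries 1-(hydroxymethyl)butyl in place of 1-(hydroxymethyl)ethyl on an amide-type nitrogen. Within the data shown here, only one measured step bears on this change, namely a number 9 percentage points lower from compound 1 to compound 2 (within the scatter) for methyl in place of hydrogen on a saturated chain carbon bound to an amide-type nitrogen. Among the measured compounds shown here, that single step is thin support, and no measured compound yet carries the longer chain. The expected step in this assay is a number 7 percentage points lower from compound 2 to compound 3 (within the scatter) and none beyond the scatter is expected. Compound 3 is estimated at 78% with an expected range from 55% to 97% for now.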

Compound 3, oral bioavailability: 103%
Compound 3: middle estimate off by 25 percentage points, on the low side; measured number outside the range, above it.
By their numbers in this assay, from the lowest: compounds 2, 1 and 3 (each within the scatter of the next, the first and the last beyond it).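

In this assay, among these compounds, the amide-type nitrogen accepts a longer substituent without loss: 1-(hydroxymethyl)butyl in place of 1-(hydroxymethyl)ethyl gives the first step beyond the scatter (a number 18 percentage points higher from compound 2 to compound 3 (beyond the scatter)). Set against the compound without a chain substituent, propyl in place of hydrogen on the saturated chain carbon gives no separation (a number 9 percentage points higher from compound 1 to compound 3 (within the scatter)), so this carbon tolerates propyl as well as hydrogen in this read-out. Nothing at hand accounts for the rise from the shorter to the longer substituent.

Since 1-(hydroxymethyl)butyl also brings a defined stereocentre, the compounds shown do not separate the effect of chain length from that of the stereocentre. Also open, on these data alone, is how a longer chain, such as 1-(hydroxymethyl)pentyl, or an amine or a carboxylic acid in place of the hydroxymethyl would read at this position.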